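Would a hydroxy move compound 2 off its limit?

The compounds below may be only part of what the source reports. "The series", "measured", "known", "first", "only" and "open" are said of these compounds alone.

Compound 2 (`Cn1c(-c2cc(-c3ccccc3)no2)cc(Br)c1Br`) stands at >= 100000 nM in a functional assay on KB403 cells (Homo sapiens) for cytotoxicity, read by MTT assay, with stated times of 6 h and 48 h (a lower number here means a stronger inhibitor, a higher number a weaker inhibitor), and this is a limit of the assay, not a number. Compound 4 (`Cn1c(-c2cc(-c3ccccc3O)no2)cc(Br)c1Br`) differs from it in one place: hydroxy in place of hydrogen on an aromatic carbon. Going by the values given here, only one measured step starts from compound 2: an at least 32-fold lower number from compound 2 to compound 3 (1.50 log units; beyond the scatter), which gives compound 3 (`Cn1c(-c2cc(-c3ccc[nH]3)no2)cc(Br)c1Br`) a value of 3100 nM. That large step swaps the whole phenyl for 1H-pyrrol-2-yl, so it is only a loose guide to adding a hydroxy. Compound 1 (`Cn1c(/C=C/C(=O)c2ccccc2O)cc(Br)c1Br`), which also carries a hydroxy on a six-membered aromatic ring of carbon only, gives 8320 nM. A smaller move towards a lower number is therefore expected, namely an at least 5.0-fold lower number from compound 2 to compound 4 (0.69 log units; beyond the scatter). The estimate for compound 4 is 20000 nM, within a range of 5000 nM to 100000 nM.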

Compound 4, half-maximal inhibitory concentration: 2450 nM
Beside the measured number, compound 4's estimate is 8.2-fold (0.91 log units) above it, and the stated range ends above it.
By their numbers in this assay, from the lowest: compounds 4 and 3 (each within the scatter of the next); then compound 1. At a limit, above all of these: compound 2.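

Adding one hydroxy to the phenyl gives an at least 40-fold lower number from compound 2 to compound 4 (1.61 log units; beyond the scatter) and shows that the whole ring need not be replaced to leave the limit. A change of a single heavy atom, on an aromatic carbon ortho to a large group, is enough. The real size of this step remains unknown, since compound 2 stands at a limit: the limit of >= 100000 nM in this assay, at which 1 of the 4 values shown sits.

On these data alone, whether the hydroxy must sit at this place on the ring remains open. So does whether a methoxy, an amine or a carboxylic acid there would do the same.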